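The source may report more compounds than this note shows. Statements on the series, on what has been measured and on what is new or still open speak of the compounds shown alone.

For the measured compounds named here, in a functional assay on isolated protein for inhibition of Glucose-dependent insulinotropic receptor (Rattus norvegicus), read by HTRF and cAMP accumulation (a higher number here means that more compound is needed for the effect, a lower number that less compound is needed), compound 1 `Cc1nc(S(C)(=O)=O)ccc1Oc1ncnc(OC2CCN(C(=O)O[C@H](C)C(F)(F)F)CC2)c1F` gives 110 nM, the second highest of the three numbers so far. Compound 2 `Cc1nc(S(C)(=O)=O)ccc1Oc1ncnc(OC2CCN(C(=O)O[C@@H](C)C(F)(F)F)CC2)c1F` gives 109 nM, and the step of a 1.0-fold lower number from compound 1 to compound 2 (0.00 log units; within the scatter) reflects (the fact that compounds 1 and 2 differ only in the configuration as drawn). Compound 3 `Cc1nc(S(C)(=O)=O)ccc1Oc1ncnc(OC2CCN(C(=O)OC3COC3)CC2)c1F` gives 2500 nM, so the step is a 23-fold higher number from compound 1 to compound 3 (1.36 log units; beyond the scatter).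

Compound 4 `Cc1nc(S(C)(=O)=O)ccc1Oc1ncnc(OC2CCN(C(=O)c3noc(C(C)(C)F)n3)CC2)c1F` differs from compound 1 in this way: a group of 9 heavy atoms (5 carbon, 2 nitrogen, 1 oxygen, 1 fluorine; one five-membered aromatic ring with 3 hetero atoms) in place of a group of 7 heavy atoms (3 carbon, 1 oxygen, 3 fluorine; no ring), on a carbonyl carbon. Going by the values given here, the only measured step at this position, a 23-fold higher number from compound 1 to compound 3 (1.36 log units; beyond the scatter), shows that replacing 1-(trifluoromethyl)ethyl on that oxygen with a ring costs a great deal in this assay. Among the compounds with values here, compound 4 exchanges the whole 1-(trifluoromethyl)ethoxy group for an aromatic group, which no measured pair covers directly, so the expectation is a higher number than compound 1, of uncertain size. Compound 4 is therefore expected to give about 350 nM, with a range from 80 nM to 1500 nM. The step this estimate implies is a 3.2-fold higher number from compound 1 to compound 4 (0.50 log units; beyond the scatter).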

Compound 4, half-maximal effective concentration: 103 nM
Estimate against measurement, compound 4: 3.4-fold (0.53 log units) above; the measured number falls inside the stated range.
By their numbers in this assay, from the lowest: compounds 4, 2 and 1 (each within the scatter of the next); then compound 3.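

At the carbonyl carbon, the group with the five-membered aromatic ring stands in for 1-(trifluoromethyl)ethoxy with no change beyond the scatter, with a 1.1-fold lower number from compound 1 to compound 4 (0.03 log units; within the scatter) and a 1.1-fold lower number from compound 2 to compound 4 (0.02 log units; within the scatter), so that particular group is not required at this place. The large loss seen with oxetan-3-yl therefore does not extend to every ring-bearing group here, as a 24-fold lower number from compound 3 to compound 4 (1.39 log units; beyond the scatter) shows. Nothing measured here explains why the two groups give matching numbers.

On these data alone, it remains open whether the aromatic ring alone accounts for this result, and how an amine or a carboxylic acid would fare on the same carbonyl carbon.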